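The source may hold more compounds than are shown below. What is called first, only, known or untested is meant among the compounds shown, and "the series" means these compounds.

Of the compounds shown here, three have been measured in a functional assay on Jurkat cells (Homo sapiens) for cytotoxicity, read by luminescence and CellTiter-Glo, with a stated time of 3 days; on this read-out higher numbers stand for weaker inhibition and lower numbers for stronger inhibition. Compound 1, `O=C(Nc1ccc([N+](=O)[O-])cc1)c1cc(F)ccc1O`, gives 940 nM in this assay, the highest of the three numbers. Compound 2, `N#Cc1ccc(NC(=O)c2ccc3cccnc3c2O)cc1`, gives 180 nM in this assay. Compound 3, `N#Cc1ccc(NC(=O)c2ccc3cccnc3c2O)c(Cl)c1`, gives 550 nM in this assay. Compound 1 and compound 3 lie within the usual scatter of each other, so nothing is said about their order; against compound 2, compound 1 stands beyond the scatter.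

Among the compounds with values here, the one measured step is a 3.1-fold higher number from compound 2 to compound 3 (0.49 log units; beyond the scatter), the change being (chloro in place of hydrogen on an aromatic carbon).

Compound 4, `O=C(Nc1ccc([N+](=O)[O-])cc1Cl)c1cc(F)ccc1O`, is not yet measured. It differs from compound 1 by chloro in place of hydrogen on an aromatic carbon. The difference between the core of compound 1 and the core of compound 2 is not broken down here. The change from compound 1 to compound 4 is the same kind of change as that from compound 2 to compound 3, but not the same: in compound 3 the chloro sits meta to a cyano group, whereas in compound 4 it sits meta to a nitro group.

Within the data shown here, because the step of a 3.1-fold higher number from compound 2 to compound 3 (0.49 log units; beyond the scatter) went modestly upward, a comparable upward step is expected for compound 4 in this assay, and the estimate means a step of a 2.7-fold higher number from compound 1 to compound 4 (0.42 log units; beyond the scatter), resting on the one measured precedent alone. The expected value for compound 4 in this assay is 2500 nM, with an estimated range from 1000 nM to 6500 nM.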

Compound 4, half-maximal inhibitory concentration: 530 nM
For compound 4 the middle estimate is 4.7-fold (0.67 log units) above the measured one; measured number outside the range, below it.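

In this assay, chloro in place of hydrogen on the core of compound 1 gives a 1.8-fold lower number from compound 1 to compound 4 (0.25 log units; within the scatter), so on this core the change has no effect that can be told from the usual scatter of repeated measurements. Set beside the earlier step, the same change does not carry over unchanged from one core to the other in this series: the same change on two cores in this assay, a 3.1-fold higher number (0.49 log units; beyond the scatter) from compound 2 to compound 3 and a 1.8-fold lower number (0.25 log units; within the scatter) from compound 1 to compound 4, 5.4-fold (0.73 log units) apart, beyond the scatter of two such steps. Within the data shown here, this does not show what sets the two steps apart: there is only one pair on each core, the difference between the two cores is not broken down, and no rule for a further core follows from two pairs.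

The compounds shown leave open whether the outcome of the step follows the nitro group or the rest of the core, a question that the core of compound 2 with a nitro group in place of its nitrile would address. They also leave open whether another group on the same aromatic carbon, such as methyl, methoxy or bromo, would follow chloro on either core.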